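Aryl Variation on the Shared Core: Estimating Compound 4

The compounds below may be only part of what the source reports. "The series", "measured", "known", "first", "only" and "open" are said of these compounds alone.

Three measured analogues share one core. In a functional assay on KB cells (Homo sapiens) for antiproliferative activity, read by sulforhodamine B assay, with a stated time of 3 days (on this read-out higher numbers stand for an effect only at larger amounts of compound and lower numbers for an effect already at smaller amounts), compound 1 `CCC1=C(O)c2c(oc(-c3ccc(CC(C)C)cc3)cc2=O)C(CC)(CC)C1=O` gives 29.3 uM; compound 2 `CCC1=C(O)c2c(oc(-c3ccc(O)cc3)cc2=O)C(CC)(CC)C1=O` gives 20.6 uM; compound 3 `CCC1=C(O)c2c(oc(-c3cccc(C(F)(F)F)c3)cc2=O)C(CC)(CC)C1=O` gives 35.7 uM. Compound 2 carries the lowest of the three numbers, yet its gaps to compound 1 and to compound 3 both lie within the scatter, so no order among the three is claimed. Among the compounds with values here, the single one-point step, a 1.4-fold lower number from compound 1 to compound 2 (0.15 log units; within the scatter), is likewise within the scatter.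

Compound 4 `CCC1=C(O)c2c(oc(-c3ccccc3C)cc2=O)C(CC)(CC)C1=O` arises from compound 2 by 2-methylphenyl in place of 4-hydroxyphenyl on an aromatic carbon. Within the data shown here, only the step from compound 1 to compound 2 bears on this change, and it was small, with compound 3 at a similar level. No shift beyond the scatter is therefore expected in this assay. Compound 4 is estimated at 27 uM, within 13 uM to 60 uM. The expected step is a 1.3-fold higher number from compound 2 to compound 4 (0.12 log units; within the scatter).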

Compound 4, concentration for half-maximal effect: 40.9 uM
For compound 4 the middle estimate is 1.5-fold (0.18 log units) below the measured one, within the range that was stated.
By their numbers in this assay, from the lowest: compounds 2, 1, 3 and 4 (each within the scatter of the next).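

Working notes: in this assay the exchange on the aromatic carbon next to the ring oxygen gives a 2.0-fold higher number from compound 2 to compound 4 (0.30 log units; within the scatter) and so stays within the scatter. 2-Methylphenyl has 0 hydrogen-bond donors and 0 hydrogen-bond acceptors where 4-hydroxyphenyl has 1 of each, so this change in those counts brought no shift beyond the scatter here. No evidence on the origin of this result is at hand.

Open: whether an amine or a carboxylic acid on this aryl ring would move the number beyond the scatter. Also open is whether any group at this position separates clearly from the four compounds shown.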